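Hydrazide-to-hydrazone variants on the shared core: cytotoxicity notes

A few compounds are considered here, and "the series" means these few. Any claim that something is new, unique, unknown or untested is made for them only; others in the source may bear on it.

Measured so far in a functional assay on BGC-823 cells (Homo sapiens) for cytotoxicity, read by MTT assay, with a stated time of 48 h; on this read-out lower numbers stand for stronger inhibition and higher numbers for weaker inhibition:
compound 1 `NNC(=O)CSc1nnc(-c2ccncc2)o1`: 3260 nM
compound 2 `COc1ccc(/C=N/NC(=O)CSc2nnc(-c3ccncc3)o2)cc1`: 19800 nM
compound 3 `O=C(CSc1nnc(-c2ccncc2)o1)N/N=C/c1cccc(C(F)(F)F)c1`: 13000 nM

Compound 2 gives the highest of the three numbers in this assay. Its gap to compound 3 lies within the scatter, so no order between the two is claimed. Its gap to compound 1 lies beyond the scatter, and compound 1 stands clearly lower.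

Compound 4 `O=C(CSc1nnc(-c2ccncc2)o1)N/N=C/c1ccccc1O` is not yet measured. It differs from compound 2 by 2-hydroxyphenyl in place of 4-methoxyphenyl on a carbon with a double bond to nitrogen. Within the data shown here, no step between measured compounds isolates this change. Compound 2 and compound 3, which both carry an aromatic ring on the carbon with a double bond to nitrogen, sit well above compound 1, and compound 4 is expected to stay in that region. The step of a 1.7-fold lower number from compound 2 to compound 4 (0.22 log units; within the scatter) is expected to be small, if anything toward a lower number, and not beyond the scatter. Compound 4 is estimated at 12000 nM, with a range from 4000 nM to 35000 nM.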

Compound 4, half-maximal inhibitory concentration: 6160 nM
Compound 4: middle estimate off by 1.9-fold (0.29 log units), on the high side, within the range that was stated.
By their numbers in this assay, from the lowest: compounds 1 and 4 (each within the scatter of the next); then compounds 3 and 2 (each within the scatter of the next).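

Among these compounds, changing the aromatic group on the carbon with a double bond to nitrogen can shift the read-out: 2-hydroxyphenyl in place of 4-methoxyphenyl gives a 3.2-fold lower number from compound 2 to compound 4 (0.51 log units; beyond the scatter) in this assay and is the only step read so far at this position. The change swaps one group for another and also alters where it sits on the ring, so this single step cannot separate the two. No measurement shown accounts for the step.

Still open, from the compounds shown here alone, is how an amine or a carboxylic acid on this aromatic ring would read. Going by these compounds, a longer chain in its place is equally open.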